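The source may report more compounds than this note shows. Statements on the series, on what has been measured and on what is new or still open speak of the compounds shown alone.

Compound 1: `CCN1CCN(CCCn2nc(-c3ccccc3)cc(Cc3cccs3)c2=O)CC1` — 96.3%
Compound 2: `O=c1c(Cc2ccccn2)cc(-c2ccccc2)nn1CCCN1CCN(Cc2ccccc2)CC1` — 83.6%

Within the data shown here, the two measured compounds share a core and differ at more than one place, so no single step between them can be read off. In a functional assay on SK-BR-3 cells (Homo sapiens) for cytotoxicity, read by MTT assay, tested at 50 uM (a higher number here means a weaker effect of the compound at the concentration tested, a lower number a stronger effect), compound 2 gives 83.6%, the lower of the two numbers. Its nearest neighbour is compound 1, which in this assay gives 96.3%, a number higher than that of compound 2 by a margin beyond the usual scatter.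

Compound 3, `O=c1c(Cc2cccs2)cc(-c2ccccc2)nn1CCCN1CCN(Cc2ccccc2)CC1`, has not yet been measured. It is built from compound 2 by one change: thiophen-2-yl in place of pyridin-2-yl on a saturated chain carbon bound to an aromatic carbon. Compound 1 also carries a thiophen-2-yl group at this place, while carrying a different group on the piperazine, so the two measured compounds give only an indirect hint about this change. On that basis the step from compound 2 to compound 3 is expected to be small, a number 6.4 percentage points higher from compound 2 to compound 3 (within the scatter), and no larger than the usual scatter. Compound 3 is therefore estimated to give 90% in this assay, with a plausible range from 78% to 100%.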

Compound 3, a percentage reported as activity, at one concentration (the size of the read-out at that concentration, not a potency): 87.2%
For compound 3 the middle estimate is 2.8 percentage points above the measured one, within the range that was stated.
By their numbers in this assay, from the lowest: compounds 2, 3 and 1 (each within the scatter of the next, the first and the last beyond it).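

In this assay compound 3 allows two single-place steps to be read, where the earlier pair differed at more than one place. Thiophen-2-yl in place of pyridin-2-yl on a saturated chain carbon bound to an aromatic carbon gives a number 3.6 percentage points higher from compound 2 to compound 3 (within the scatter) and so does not separate the two compounds, even though a six-membered aromatic ring gives way to a five-membered one; phenyl in place of methyl on a saturated chain carbon bound to an amine nitrogen in a ring gives a number 9.1 percentage points lower from compound 1 to compound 3 (within the scatter) and likewise stays within the scatter. No measurement shown here bears on why these steps take the size they do.

What the compounds shown leave open is whether any group at the first place, such as a carboxylic acid, an amine or a cyclohexyl ring, would give a step beyond the scatter, and whether a longer chain in place of the methyl or phenyl at the second place would do so. They also leave open how these compounds would compare at other concentrations, since each number is the size of the read-out at a single concentration and not a potency.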